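Replacing the Side Arm on a Shared Core

This account rests on a few compounds, and the source may have more. Where it says the series, first, only, none or still open, it means among the compounds named here.

Three compounds share one core and differ only in the group hanging from it. In an assay on isolated protein for inhibition of Rho-associated protein kinase 2 (Homo sapiens), read by ELISA, with a stated time of 30 min, tested at 10 uM, in the presence of a further agent that is not named here (on this read-out higher numbers stand for more inhibition at the one concentration tested (going by the name of the read-out) and lower numbers for less inhibition), compound 1 `CN(C)C(=O)Cc1sc(NC(=O)c2ccncc2)nc1-c1ccncc1` gives 38.1%, compound 2 `O=C(Nc1nc(-c2ccncc2)c(CN2CCCC2)s1)c1ccncc1` gives 47.6%, and compound 3 `O=C(Nc1nc(-c2ccncc2)c(CN2CCCCC2)s1)c1ccncc1` gives 48.2%. Compound 3 holds the highest of the three numbers, yet a number 0.6 percentage points higher from compound 2 to compound 3 (within the scatter) is within the scatter; only a number 10.1 percentage points higher from compound 1 to compound 3 (beyond the scatter) lies beyond it, while a number 9.5 percentage points higher from compound 1 to compound 2 (within the scatter) does not. Compound 4 `CN1CCN(c2sc(NC(=O)c3ccncc3)nc2-c2ccncc2)CC1` differs from compound 3 by 4-methylpiperazin-1-yl in place of (piperidin-1-yl)methyl on an aromatic carbon. Among the measured compounds shown here, none of the measured steps alters the same place in the same way: each swapped a group on a saturated chain carbon, and all were small. Compound 4 is therefore expected to give about 42%, likely between 25% and 60%. This amounts to an expected step of a number 6.2 percentage points lower from compound 3 to compound 4 (within the scatter).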

Compound 4, a percentage reported as inhibition, at one concentration (the size of the read-out at that concentration, not a potency): 34.3%
Compound 4: the middle estimate sits 7.7 percentage points above what was measured; measured number inside the range.
By their numbers in this assay, from the lowest: compounds 4, 1, 2 and 3 (each within the scatter of the next, the first and the last beyond it).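

Placing 4-methylpiperazin-1-yl directly on this aromatic carbon brings no gain over the side arms held on a saturated chain carbon: the change gives a number 13.9 percentage points lower from compound 3 to compound 4 (beyond the scatter) and a number 13.3 percentage points lower from compound 2 to compound 4 (beyond the scatter), while the step from the dimethylcarbamoyl arm is a number 3.8 percentage points lower from compound 1 to compound 4 (within the scatter). Nothing available explains these differences.

The swap removes the chain carbon and adds a second ring nitrogen at once, so the compounds shown cannot separate the two. Piperidin-1-yl directly on the aromatic carbon, or (4-methylpiperazin-1-yl)methyl there, would pull them apart.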